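Adding a Bromo Group to the Unsubstituted Compound 3

A few compounds are considered here, and "the series" means these few. Any claim that something is new, unique, unknown or untested is made for them only; others in the source may bear on it.

Three analogues sharing one core have been measured in a physicochemical assay for lipophilicity, measured as octanol-water partition; a lower number here means a more polar compound, a higher number a more lipophilic compound. Compound 1 `O=C(COc1cccc2ccccc12)N/N=C/c1ccc(Cl)cc1` gives a value of 4.54 in this assay. Compound 2 `O=C(COc1cccc2ccccc12)N/N=C/c1ccccc1Br` gives 4.81 in this assay, and compound 3 `O=C(COc1cccc2ccccc12)N/N=C/c1ccccc1` gives 4.02 in this assay. Compound 3 thus stands lowest of the three, with compound 1 nearest and compound 2 furthest, both gaps beyond the scatter. The step of a number 0.27 log units higher from compound 1 to compound 2 (within the scatter) lies within the scatter, whereas the two halogen removals are larger: a number 0.52 log units lower from compound 1 to compound 3 (beyond the scatter) and a number 0.79 log units lower from compound 2 to compound 3 (beyond the scatter).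

Compound 4 `O=C(COc1cccc2ccccc12)N/N=C/c1cccc(Br)c1` differs from compound 3 by bromo in place of hydrogen on an aromatic carbon. Within the data shown here, the closest precedent runs in the opposite direction: the step from compound 2 to compound 3 removed a bromo group and lowered the number by a modest amount, and the step from compound 1 to compound 3 removed a chloro group with a somewhat smaller drop. Adding a bromo group back is therefore expected to raise the number in this assay by a modest step, a number 0.75 log units higher from compound 3 to compound 4 (beyond the scatter). Compound 4 is accordingly estimated at 4.77 in this assay, within a range from 4.45 to 5.1.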

Compound 4, partition coefficient: 4.81
The estimate for compound 4 lay 0.04 log units below the measured number; the measured number falls inside the stated range.
By their numbers in this assay, from the lowest: compound 3; then compounds 1, 2 and 4 (each within the scatter of the next).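

Bromo in place of hydrogen on an aromatic carbon, meta to a large group, gives a number 0.79 log units higher from compound 3 to compound 4 (beyond the scatter) in this assay and is the first direct reading of bromo entering the unsubstituted compound at this position; it matches in size, with the opposite sign, a number 0.79 log units lower from compound 2 to compound 3 (beyond the scatter) on the earlier bromo compound. Taking 3-bromophenyl in place of 2-bromophenyl gives no change at the digits printed from compound 2 to compound 4 (within the scatter) in this assay and shows that, for this pair, shifting the bromo leaves the read-out unresolved, so the gain over compound 3 is the same for either bromo placement shown. Taking 3-bromophenyl in place of 4-chlorophenyl gives a number 0.27 log units higher from compound 1 to compound 4 (within the scatter) and so cannot separate these two halogen-bearing rings, just as the earlier comparison with the 2-bromophenyl compound could not.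

The compounds shown carry only hydrogen, bromo or chloro on this ring, so what an amine, a carboxylic acid or a methoxy group at this position would do to the number stays open. No measured evidence is available that would explain the size of these steps.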